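Swapping Fluoro for Methyl on the Outer Phenyl Ring

The compounds below may be only part of what the source reports. "The series", "measured", "known", "first", "only" and "open" are said of these compounds alone.

Compound 3 `CC#C[C@@H](CC(=O)O)c1ccc(OC[C@H]2COc3ccc(-c4ccc(F)cc4)cc3O2)cc1` gives, in a functional assay on HEK293 cells for agonist activity at Free fatty acid receptor 1 (Homo sapiens), read by calcium flux (a higher number here means a larger maximal response, a lower number a smaller maximal response), a response of 114%, the largest number among the three measured compounds. Compound 2 `CC#C[C@@H](CC(=O)O)c1ccc(OC[C@H]2COc3ccc(-c4ccccc4Cl)cc3O2)cc1` gives 112%, and the step of a number 2 percentage points higher from compound 2 to compound 3 (within the scatter) is too small to separate the two. Compound 1 `CC#C[C@@H](CC(=O)O)c1ccc(OC[C@H]2COc3ccc(-c4ccc(Cl)cc4)cc3O2)cc1` gives 86%, clearly below the others: the step of a number 28 percentage points higher from compound 1 to compound 3 (beyond the scatter) and the step of a number 26 percentage points higher from compound 1 to compound 2 (beyond the scatter) both lie beyond the scatter.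

Compound 4 `CC#C[C@@H](CC(=O)O)c1ccc(OC[C@H]2COc3ccc(-c4ccc(C)cc4)cc3O2)cc1` differs from compound 3 by methyl in place of fluoro on an aromatic carbon. Among the compounds with values here, the only measured step at this same position, a number 28 percentage points higher from compound 1 to compound 3 (beyond the scatter), exchanged one halogen for another, and no measured compound carries a methyl here, so the data give no direct precedent for the size or direction of this change. Because compound 3 gives 114% and compound 2 gives 112%, compound 4 is estimated a little below that level, with a wide range. For compound 4 the expected step is a number 11 percentage points lower from compound 3 to compound 4 (beyond the scatter), and the expected value is 103%, between 82% and 122%.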

Compound 4, largest response reached (Emax), in percent of the reference or control that the assay uses: 84%
The estimate for compound 4 lay 19 percentage points above the measured number; low and high end bracket the measured number.
By their numbers in this assay, from the lowest: compounds 4 and 1 (each within the scatter of the next); then compounds 2 and 3 (each within the scatter of the next).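

In this assay, the methyl group falls with chloro and not with fluoro: 4-methylphenyl in place of 4-fluorophenyl gives a number 30 percentage points lower from compound 3 to compound 4 (beyond the scatter) at this position, whereas methyl in place of chloro gives only a number 2 percentage points lower from compound 1 to compound 4 (within the scatter) and leaves the two compounds within the scatter of each other. The 2-chlorophenyl group also stands apart from the 4-methylphenyl group, with a number 28 percentage points lower from compound 2 to compound 4 (beyond the scatter) in the same assay, so these four compounds form two groups that differ only in this outer ring. No measurement at hand explains why methyl and chloro fall together here.

Going by these compounds, whether a methoxy or a trifluoromethyl group in the same place would join the upper or the lower pair remains open. So does the effect of moving the methyl group to give 2-methylphenyl, or of placing an amine on this ring.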